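Swapping naphthalen-2-yl for 3-hydroxyphenyl on a sulfur

The source may hold more compounds than are shown below. What is called first, only, known or untested is meant among the compounds shown, and "the series" means these compounds.

Measured in a functional assay on U2OS cells (Homo sapiens) for antiproliferative activity, read by MTT assay, with a stated time of 72 h; on this read-out higher numbers stand for weaker inhibition and lower numbers for stronger inhibition:
- compound 1 `O=C(CSc1cccc(O)c1)Nc1ccc2nc(NC(=O)c3ccccc3)sc2c1` gives > 100000 nM, a limit of the assay
- compound 2 `Nc1ccc(SCC(=O)Nc2ccc3nc(NC(=O)c4ccc(C(F)(F)F)cc4)sc3c2)cc1` gives 1220 nM
- compound 3 `O=C(CSc1ccc2ccccc2c1)Nc1ccc2nc(NC(=O)c3ccc(C(F)(F)F)cc3)sc2c1` gives 3940 nM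

Among the two values that are true numbers, compound 3 has the higher one, and so the weaker inhibition. Compound 4 `O=C(CSc1cccc(O)c1)Nc1ccc2nc(NC(=O)c3ccc(C(F)(F)F)cc3)sc2c1` changes one group of compound 3: 3-hydroxyphenyl in place of naphthalen-2-yl on a sulfur. In words, 3-hydroxyphenyl stands in place of naphthalen-2-yl on a sulfur.

Among the compounds with values here, only one measured step changes this same group: a 3.2-fold higher number from compound 2 to compound 3 (0.51 log units; beyond the scatter), modest but beyond the scatter. That single step suggests that swaps here need not move the number far in this assay, so no step beyond the scatter is expected, and its direction is uncertain. Compound 1 also carries 3-hydroxyphenyl on a sulfur and reads > 100000 nM, which is a limit, so the expected range for compound 4 stays wide on the high side. The expected change is a 1.6-fold lower number from compound 3 to compound 4 (0.20 log units; within the scatter). Compound 4 is estimated at 2500 nM, with an expected range from 700 nM to 15000 nM.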

Compound 4, half-maximal inhibitory concentration: 630 nM
The estimate for compound 4 lay 4.0-fold (0.60 log units) above the measured number; the whole stated range lies above it.
By their numbers in this assay, from the lowest: compounds 4 and 2 (each within the scatter of the next); then compound 3. At a limit, above all of these: compound 1.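

In this assay, this position on the sulfur clearly responds to the group it carries: a 6.3-fold lower number from compound 3 to compound 4 (0.80 log units; beyond the scatter). Both single-ring groups now read lower than naphthalen-2-yl, yet 3-hydroxyphenyl and 4-aminophenyl cannot be told apart: a 1.9-fold lower number from compound 2 to compound 4 (0.29 log units; within the scatter). The 3-hydroxyphenyl group alone does not secure activity, since the trifluoromethyl group also counts, with an at least 150-fold lower number from compound 1 to compound 4 (2.20 log units; beyond the scatter), and the starting point of that step is only a limit: the limit of > 100000 nM in this assay, at which 1 of the 4 values shown sits.

As far as these compounds go, whether the hydroxyl or amino group matters at all remains open, since a plain phenyl or a methoxyphenyl on the sulfur would be needed to tell. From the compounds shown here alone, whether trifluoromethyl has the same effect with other groups on the sulfur also remains open, as this rests on a single pair.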